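The source may report more compounds than this note shows. Statements on the series, on what has been measured and on what is new or still open speak of the compounds shown alone.

In an ADME assay on L02 cells (Homo sapiens) for antiproliferative activity, read by MTT assay, with a stated time of 48 h (a lower number here means a stronger inhibitor, a higher number a weaker inhibitor), compound 1 `C=CCN(C)C(=O)c1ccc(C(CC)(CC)c2ccc(OCCC(O)(CC)CC)c(C)c2)n1CC` gives 1190 nM. Compound 2 `CCn1c(C(=O)Nc2cccc(C(F)(F)F)c2)ccc1C(CC)(CC)c1ccc(OCCC(O)(CC)CC)c(C)c1` gives > 50000 nM, which is a limit and not a number; it stands at the limit of > 50000 nM in this assay, at which 1 of the 2 values shown sits. Compound 3 `CCn1c(C(=O)N(C)CC(=O)O)ccc1C(CC)(CC)c1ccc(OCCC(O)(CC)CC)c(C)c1` differs from compound 2 in one place, (carboxymethyl)(methyl)amino in place of (3-(trifluoromethyl)phenyl)amino on a carbonyl carbon. For the measured compounds named here, only one measured step bears on this place. That step, an at least 42-fold higher number from compound 1 to compound 2 (1.62 log units; beyond the scatter), is large and beyond the scatter, and it brought in the very group that compound 3 gives up. Compound 3 is expected to move back only part of the way toward compound 1, since the entering group is new and the starting point is only a limit. The expected change, toward a lower number, is an at least 2.0-fold lower number from compound 2 to compound 3 (0.30 log units; that floor lies within the scatter). For compound 3 the estimate is 25000 nM, with an expected range of 5000 nM to 50000 nM.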

Compound 3, half-maximal inhibitory concentration: 2150 nM
The estimate for compound 3 lay 12-fold (1.07 log units) above the measured number; the measured number lies below the stated range.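

In this assay, (carboxymethyl)(methyl)amino in place of (3-(trifluoromethyl)phenyl)amino on the carbonyl carbon gives an at least 23-fold lower number from compound 2 to compound 3 (1.36 log units; beyond the scatter), so the shared core does not by itself fix the weak reading of compound 2; the group on this carbonyl carbon can decide it. The two chains on the amide-type nitrogen cannot be told apart here, with carboxy in place of vinyl giving a 1.8-fold higher number from compound 1 to compound 3 (0.26 log units; within the scatter). Compound 2 has only a limit and not a number: the limit of > 50000 nM in this assay, at which 1 of the 3 values shown sits.

The compounds shown do not separate the aromatic ring, its trifluoromethyl group and the amide hydrogen as the source of the large steps, which a plain phenylamino group or a dimethylamino group could address. Going by these compounds, how far this position accepts other chains, such as one ending in an amine, also remains open.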